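Swapping a Side Group: Solubility of Compound 4

The compounds below may be only part of what the source reports. "The series", "measured", "known", "first", "only" and "open" are said of these compounds alone.

Values in a physicochemical assay for solubility, read by spectrophotometry, in phosphate buffer, with a stated time of 2 h, at pH 7.4; on this read-out higher numbers stand for higher solubility and lower numbers for lower solubility:
- compound 1 `COc1ccc2[nH]c(C(=O)N3CC(=O)N(Cc4ccccc4)[C@@H](CN4CCC5(CC4)CC5)C3)cc2c1`: 28200 nM
- compound 2 `COc1ccc2[nH]c(C(=O)N3CC(=O)N(Cc4ccccc4)[C@@H](COCc4ccccc4)C3)cc2c1`: 8800 nM
- compound 3 `COc1ccc2[nH]c(C(=O)N3CC(=O)N(Cc4ccccc4)[C@@H](CN4CCC(OC)CC4)C3)cc2c1`: > 25000 nM (a limit)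

Compound 3 stands at the limit of > 25000 nM in this assay, at which 1 of the 3 values shown sits. The unmeasured compound 4 `COc1ccc2[nH]c(C(=O)N3CC(=O)N(Cc4ccccc4)[C@@H](CCN4CCC5(CC4)CC5)C3)cc2c1` differs from it as follows: a group of 9 heavy atoms (8 carbon, 1 nitrogen; one three-membered non-aromatic ring of carbon only, one six-membered non-aromatic ring with 1 hetero atom) in place of a group of 8 heavy atoms (6 carbon, 1 nitrogen, 1 oxygen; one six-membered non-aromatic ring with 1 hetero atom), on a saturated chain carbon bound to a saturated ring carbon. The most relevant measured step is a step that the limit leaves unreadable from compound 1 to compound 3. The steps through the benzyloxy group are a 3.2-fold lower number from compound 1 to compound 2 (0.51 log units; beyond the scatter) and an at least 2.8-fold higher number from compound 2 to compound 3 (0.45 log units; beyond the scatter), but compound 4 lacks that group. Compound 1 also carries one three-membered non-aromatic ring of carbon only and one six-membered non-aromatic ring with 1 hetero atom, and it gives 28200 nM. No step beyond the scatter is therefore expected, and the estimated change is an at least 1.2-fold lower number from compound 3 to compound 4 (0.09 log units; that floor lies within the scatter). Compound 4 is estimated at 20000 nM, with an expected range from 8000 nM to 40000 nM.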

Compound 4, solubility: > 25000 nM
Compound 4 was reported as a limit (the forecaster's own chance of this, stated with the estimate: 35%); at least 1.2-fold (0.09 log units) between middle value and limit.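

Placed on a saturated chain carbon bound to a saturated ring carbon, the group of 9 heavy atoms in place of benzyloxy gives an at least 2.8-fold higher number from compound 2 to compound 4 (0.45 log units; beyond the scatter) in this assay, so a second side group without benzyloxy also reads clearly higher than compound 2. The steps from compound 1 and from compound 3 to compound 4 cannot be read. Compound 4 is reported only as a limit: the limit of > 25000 nM in this assay, at which 2 of the 4 values shown sit.

Still open, as far as these compounds go, is how far compound 3 and compound 4 lie past that limit. Also open, from the compounds shown here alone, is how a morpholine or a carboxylic acid in this place would read in this assay.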